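From methyl to methoxy on compound 3

The compounds below may be only part of what the source reports. "The series", "measured", "known", "first", "only" and "open" are said of these compounds alone.

In a functional assay (HSMC cells, Homo sapiens) for antiproliferative activity, with a stated time of 72 h (on this read-out higher numbers stand for weaker inhibition and lower numbers for stronger inhibition), compound 1 `COC(=O)CNC(=O)c1ccc(OC[C@@H]2COc3ccccc3O2)cc1-c1ccccc1OC` gives 35000 nM, compound 2 `COC(=O)[C@H](CC(C)C)NC(=O)c1ccc(OC[C@H]2COc3ccccc3O2)cc1-c1ccccc1C` gives 3000 nM and compound 3 `COC(=O)[C@H](CC(C)C)NC(=O)c1ccc(OC[C@@H]2COc3ccccc3O2)cc1-c1ccccc1C` gives 5200 nM. Compound 3 therefore lies within the scatter of compound 2, while compound 1 has a clearly higher number, meaning weaker inhibition.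

Compound 4 `COC(=O)[C@H](CC(C)C)NC(=O)c1ccc(OC[C@@H]2COc3ccccc3O2)cc1-c1ccccc1OC` is compound 3 with one change, methoxy in place of methyl on an aromatic carbon, ortho to a large group. For the measured compounds named here, the only measured step between close relatives is a 1.7-fold higher number from compound 2 to compound 3 (0.24 log units; within the scatter), and it concerns (the fact that compounds 2 and 3 differ only in the configuration as drawn), so it does not test this swap. Compound 1, at 35000 nM, carries the same 2-methoxyphenyl group as compound 4 but also differs elsewhere, so it only widens the expected range towards higher numbers.

No shift beyond the scatter is expected, and the estimated step is a 1.2-fold higher number from compound 3 to compound 4 (0.06 log units; within the scatter). For compound 4 the estimate is 6000 nM, with the result expected between 2000 nM and 18000 nM.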

Compound 4, half-maximal inhibitory concentration: 17000 nM
Beside the measured number, compound 4's estimate is 2.8-fold (0.45 log units) below it, within the range that was stated.
By their numbers in this assay, from the lowest: compounds 2 and 3 (each within the scatter of the next); then compound 4; then compound 1.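

In this assay, methoxy in place of methyl on this aromatic carbon, ortho to a large group, is not a neutral exchange: the step is a 3.3-fold higher number from compound 3 to compound 4 (0.51 log units; beyond the scatter), so here the 2-methylphenyl compound gives the stronger inhibition. With the 2-methoxyphenyl group held constant, the step of a 2.1-fold lower number from compound 1 to compound 4 (0.31 log units; beyond the scatter) shows that isobutyl in place of hydrogen on the saturated chain carbon goes with stronger inhibition, so the number also responds to that part of the molecule, though this step is modest. Nothing at hand explains why the swap to methoxy raises the number.

Going by these compounds, only methyl and methoxy appear at this place, so it remains open how a hydroxyl group, a chlorine atom or an ethyl group would read out there. On these data alone, it is also open whether the swap gives a similar step with the ring stereocentre drawn as in compound 2.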